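The compounds below may be only part of what the source reports. "The series", "measured", "known", "first", "only" and "open" are said of these compounds alone.

Compound 1 `NC(=O)c1ccc(Cn2cc(-c3ccc4cn[nH]c4c3)ccc2=O)cc1`: in an assay for inhibition of MAP kinase-interacting serine/threonine-protein kinase 1 (Homo sapiens), read by luminescence and ADP-Glo, with a stated time of 2 h (a lower number here means a stronger inhibitor, a higher number a weaker inhibitor), compound 1 gives only a limit of the assay, > 2000 nM.
Compound 2 `Nc1n[nH]c2cc(-c3ccc(=O)n(Cc4cccc(Cl)c4)c3)ccc12`: in this assay compound 2 gives 11 nM.
Compound 3 `Cn1ncc2ccc(-c3ccc(=O)n(Cc4ccccc4)c3)cc21`: in this assay compound 3 gives only a limit of the assay, > 2000 nM.

Among these three, compound 2 is the only one with an actual number; the other two sit at the limit of > 2000 nM in this assay, at which 2 of the 3 values shown sit, so nothing can be said about how far apart they and compound 2 really are, beyond the fact that compound 2 is the one that was quantified.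

Compound 4 `Nc1n[nH]c2cc(-c3ccc(=O)n(Cc4cccc(F)c4)c3)ccc12` has not yet been measured. It differs from compound 2 in a single place: fluoro in place of chloro on an aromatic carbon, so the 3-chlorobenzyl of compound 2 becomes a 3-fluorobenzyl. Among the measured compounds shown here, no measured pair in this set shows what such a swap does, so the expectation rests on compound 2 alone. A change of one halogen for another is expected to move the result only a little, most likely within the usual scatter, with at most a slight loss. Compound 4 is therefore estimated at 20 nM, with a range from 7 nM to 60 nM, meaning an expected step of a 1.8-fold higher number from compound 2 to compound 4 (0.26 log units; within the scatter).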

Compound 4, half-maximal inhibitory concentration: 19 nM
The estimate for compound 4 lay 1.1-fold (0.02 log units) above the measured number, within the range that was stated.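

In this assay, among the compounds shown here, the swap of chloro for fluoro gives a 1.7-fold higher number from compound 2 to compound 4 (0.24 log units; within the scatter), the first comparison here between compounds that differ in one place. At this place on the benzyl group, the two halogens therefore cannot be told apart, and activity at this level does not depend on chlorine in particular. Nothing measured here says why the two halogens give such similar results.

The compounds shown leave open whether this place needs a halogen at all, and what a plain hydrogen, a methoxy group or a nitrile would do there. Also open, as far as these compounds go, is the role of the amino group on the core of compound 2: compound 1 and compound 3 lack it, but each also differs from compound 2 elsewhere, so their limits cannot be tied to any single part.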